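Ethyl on the carbamoyl nitrogen: fluoro and chloro benzyl pairs

This account rests on a few compounds, and the source may have more. Where it says the series, first, only, none or still open, it means among the compounds named here.

Working notes on a small set of piperazine dithiocarbamates carrying a substituted benzyl triazole. The shared core is varied at two places: the amide-type nitrogen of the carbamoyl group and the aromatic carbon of the benzyl ring. Compound 1 `NC(=O)N1CCN(C(=S)SCc2cn(Cc3ccc(F)cc3)nn2)CC1` is the parent with a free carbamoyl group and a fluoro substituent; in a functional assay on EC9706 cells (Homo sapiens) for cytotoxicity, read by MTT assay, with a stated time of 72 h (on this read-out higher numbers stand for weaker inhibition and lower numbers for stronger inhibition), compound 1 gives 62700 nM. Compound 2 `CCNC(=O)N1CCN(C(=S)SCc2cn(Cc3ccc(F)cc3)nn2)CC1` differs by ethyl in place of hydrogen on an amide-type nitrogen and in this assay compound 2 gives 27800 nM, so that a 2.3-fold lower number from compound 1 to compound 2 (0.35 log units; beyond the scatter). Compound 3 `NC(=O)N1CCN(C(=S)SCc2cn(Cc3ccc(Cl)cc3)nn2)CC1` differs from compound 1 by chloro in place of fluoro on an aromatic carbon. In this assay compound 3 reaches only a limit of the assay, > 128000 nM, and no number is known for it. Accordingly an at least 2.0-fold higher number from compound 1 to compound 3 (0.30 log units; that floor lies within the scatter), and the size of that step is bounded by the limit of > 128000 nM in this assay, at which 1 of the 3 values shown sits, rather than measured.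

Compound 4 `CCNC(=O)N1CCN(C(=S)SCc2cn(Cc3ccc(Cl)cc3)nn2)CC1` remains to be measured. It differs from compound 3 by ethyl in place of hydrogen on an amide-type nitrogen, the same kind of change as that from compound 1 to compound 2, and the place is the same word for word. Going by the values given here, the expectation for the step from compound 3 to compound 4 in this assay is an at least 1.4-fold lower number from compound 3 to compound 4 (0.15 log units; that floor lies within the scatter), resting on a 2.3-fold lower number from compound 1 to compound 2 (0.35 log units; beyond the scatter) as the only measured instance of the change, with the reservation that compound 3 itself is known only as a limit. Compound 4 is thus estimated at 90000 nM, within a range from 40000 nM to 200000 nM, and the assay may again report only a limit for compound 4.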

Compound 4, half-maximal inhibitory concentration: > 128000 nM
Compound 4: a limit, no number (the forecaster's own chance of this, stated with the estimate: 40%); middle value at least 1.4-fold (0.15 log units) away from the limit.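

In this assay the ethyl change cannot be read on the chloro core, and the reason is the assay limit shared by compound 3 and compound 4: the limit of > 128000 nM in this assay, at which 2 of the 4 values shown sit. Chloro in place of fluoro can be read on the ethylcarbamoyl core, as an at least 4.6-fold higher number from compound 2 to compound 4 (0.66 log units; beyond the scatter), and it points the same way on the carbamoyl core, but agreement in direction is all that is shown, not agreement in size: the same change on two cores in this assay, an at least 2.0-fold higher number (0.30 log units; that floor lies within the scatter) from compound 1 to compound 3 and an at least 4.6-fold higher number (0.66 log units; beyond the scatter) from compound 2 to compound 4; the limit leaves it open whether they differ. Going by these compounds alone, nothing here shows that the ethyl change carries from the fluoro core to the chloro core, and its only readable instance remains a 2.3-fold lower number from compound 1 to compound 2 (0.35 log units; beyond the scatter) on the fluoro core.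

The compounds shown leave open how far beyond the limit compound 3 and compound 4 lie, and so whether ethyl does anything at all when chloro is present. They also leave open whether a bromo group or an unsubstituted carbon in that aromatic place, or a longer chain such as propyl on the amide-type nitrogen, would give values that can be read on both cores and allow the two changes to be compared in size.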